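From thiophen-2-yl to 3,4,5-trimethoxyphenyl on the shared core

The source may hold more compounds than are shown below. What is called first, only, known or untested is meant among the compounds shown, and "the series" means these compounds.

Compound 1 `COc1cc(/C=C/C(=O)/C=C/c2cccs2)ccc1OCc1cn(CCCCCOc2cc(=O)oc3ccccc23)nn1` gives 30% 
Compound 2 `COc1cc(/C=C/C(=O)/C=C/c2cccs2)ccc1OCc1cn(CCCCOc2cc(=O)oc3ccccc23)nn1` gives 40% 

For the measured compounds named here, both values come from a functional assay on COLO 205 cells (Homo sapiens) for inhibition, read by sulforhodamine B assay, with a stated time of 48 h, tested at 50 uM (on this read-out lower numbers stand for less inhibition of growth and higher numbers for more inhibition of growth at the one concentration tested), and lie within the usual scatter of each other, so the numbers so far do not separate compound 1 from compound 2. Compound 3 `COc1cc(/C=C/C(=O)/C=C/c2cc(OC)c(OC)c(OC)c2)ccc1OCc1cn(CCCCCOc2cc(=O)oc3ccccc23)nn1` is still unmeasured. Set against compound 1, it carries 3,4,5-trimethoxyphenyl in place of thiophen-2-yl on a double-bonded chain carbon bound to a double-bonded chain carbon, a change that counts as 3,4,5-trimethoxyphenyl in place of thiophen-2-yl on a double-bonded chain carbon bound to a double-bonded chain carbon with the rest of the structure unchanged.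

Going by the values given here, no measured pair shows a change of this kind, so the data offer no direct guide to its size in this assay and the range must stay wide. A small upward step, not clearly beyond the scatter, is expected: the estimated a number 10 percentage points higher from compound 1 to compound 3 (within the scatter) on this read-out. For compound 3 the estimated value is 40% with an expected range from 20% to 65% on this read-out.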

Compound 3, percent growth inhibition at one concentration: 51%
For compound 3 the middle estimate is 11 percentage points below the measured one; low and high end bracket the measured number.
By their numbers in this assay, from the lowest: compounds 1 and 2 (each within the scatter of the next); then compound 3.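

In this assay, for the compounds shown here, putting 3,4,5-trimethoxyphenyl in place of thiophen-2-yl on a double-bonded chain carbon bound to a double-bonded chain carbon gives a number 21 percentage points higher from compound 1 to compound 3 (beyond the scatter), the first step here to clear the scatter. The earlier pair, compound 1 and compound 2, differ only in the chain and were not separated, whereas this result shows that the read-out does respond to the group at this position. No supporting evidence is available to explain the step.

A single exchange cannot show whether the gain belongs to the three methoxy groups or to the six-membered aromatic ring, which an unsubstituted phenyl or a 4-methoxyphenyl group would help to separate. As far as these compounds go, it also remains open whether the same step would hold on the chain of compound 2, or whether a dimethylamino group on the ring would fit this position.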